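This account rests on a few compounds, and the source may have more. Where it says the series, first, only, none or still open, it means among the compounds named here.

The shared core is carried unchanged through this small set; compound 2 `CC1(Nc2ccc(NC(=O)c3cc(Cl)ccc3O)c(Cl)c2)CCCC1` bears a 1-methylcyclopentyl group on a nitrogen on an aromatic ring. Among the compounds with values here, in an ADME assay on A549 cells (Homo sapiens) for cytotoxicity, read by resazurin assay, with a stated time of 48 h (a higher number here means that more compound is tolerated, a lower number that less compound is tolerated), compound 2 gives 157000 nM, the higher of the two numbers measured so far, while compound 3 `O=C(Nc1ccc(NCc2cc(F)cc(Cl)c2)cc1Cl)c1cc(Cl)ccc1O` gives 11100 nM. In this assay compound 1 `CC(=O)Nc1ccc(NC(=O)c2cc(Cl)ccc2O)c(Cl)c1` stands as "not determined" (no result reported), so it carries no number. Within the data shown here, the single measured step, a 14-fold lower number from compound 2 to compound 3 (1.15 log units; beyond the scatter), is the only one that bears on the question here, and it replaces the same group with a 3-chloro-5-fluorobenzyl group. Compound 4 `CC(CCO)Nc1ccc(NC(=O)c2cc(Cl)ccc2O)c(Cl)c1` differs from compound 2 as follows: 3-hydroxy-1-methylpropyl in place of 1-methylcyclopentyl on a nitrogen on an aromatic ring. Among the measured compounds shown here, the group entering in compound 4 is not the one that entered in compound 3, so that large step offers no direct guide, and the measurements give no reason to expect a shift of that size from the present change. Compound 4 is therefore expected to give 180000 nM in this assay, within a range of 80000 nM to 400000 nM, which amounts to an expected 1.1-fold higher number from compound 2 to compound 4 (0.06 log units; within the scatter), a step within the usual scatter.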

Compound 4, half-maximal cytotoxic concentration: 200000 nM
Compound 4: middle estimate off by 1.1-fold (0.05 log units), on the low side; low and high end bracket the measured number.
By their numbers in this assay, from the lowest: compound 3; then compounds 2 and 4 (each within the scatter of the next).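

In this assay, exchanging the ringed 1-methylcyclopentyl group for the open-chain 3-hydroxy-1-methylpropyl group, which brings in a hydrogen-bond donor and a hydrogen-bond acceptor, gives a 1.3-fold higher number from compound 2 to compound 4 (0.11 log units; within the scatter). On this nitrogen on an aromatic ring, then, these two quite different groups read alike, while the 3-chloro-5-fluorobenzyl group stands apart, with an 18-fold higher number from compound 3 to compound 4 (1.26 log units; beyond the scatter). No measurement at hand explains either step.

On these data alone, it remains open whether the lower number of compound 3 goes with the benzyl ring itself or with its chlorine and fluorine, a question that a plain benzyl group could help to separate. Also open, as far as these compounds go, is how an amine or a carboxylic acid in place of the hydroxy group would read in this assay.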